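This account rests on a few compounds, and the source may have more. Where it says the series, first, only, none or still open, it means among the compounds named here.

Of the compounds shown here, three built on a shared core have been tested in a functional assay on MDA-MB-435 cells (Homo sapiens) for cytotoxicity, read by sulforhodamine B assay, with a stated time of 48 h; on this read-out higher numbers stand for weaker inhibition of growth and lower numbers for stronger inhibition of growth. Compound 1 `Nc1nc(Cl)c2ncn(Cc3ccc(CCl)cc3)c2n1` gives 16600 nM. Compound 3 `ClCc1ccc(Cn2cnc3c(Cl)nc(Cl)nc32)cc1` gives 12600 nM in this assay. Compound 2 `ClCc1cccc(Cn2cnc3c(Cl)nc(Cl)nc32)c1` gives 1690 nM in this assay, the lowest of the three, with its steps to compound 3 and compound 1 both beyond the scatter. Compound 2 and compound 3 contain the same atoms joined differently; the difference between the two cores is not broken down here. The change amino in place of chloro on an aromatic carbon produced a 1.3-fold higher number from compound 3 to compound 1 (0.12 log units; within the scatter). Compound 4 `Nc1nc(Cl)c2ncn(Cc3cccc(CCl)c3)c2n1` is not yet measured; it differs from compound 2 by amino in place of chloro on an aromatic carbon, the same change at a place described in the same words. Because compound 2 gives 1690 nM and the earlier step was a 1.3-fold higher number from compound 3 to compound 1 (0.12 log units; within the scatter), compound 4 is expected to show a 1.3-fold higher number from compound 2 to compound 4 (0.11 log units; within the scatter), a step within the scatter. The estimate for compound 4 is 2200 nM, between 1000 nM and 5000 nM.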

Compound 4, concentration for 50% growth inhibition: 3810 nM
Compound 4: middle estimate off by 1.7-fold (0.24 log units), on the low side, within the range that was stated.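

In this assay, putting amino in place of chloro on an aromatic carbon gave a 2.3-fold higher number from compound 2 to compound 4 (0.35 log units; beyond the scatter), a modest step. Set beside the earlier step on the other core, the two steps cannot be told apart: the same change on two cores in this assay, a 1.3-fold higher number (0.12 log units; within the scatter) from compound 3 to compound 1 and a 2.3-fold higher number (0.35 log units; beyond the scatter) from compound 2 to compound 4, 1.7-fold (0.23 log units) apart, within the scatter of two such steps So the change behaved alike on these two cores, even though only one of its steps lies beyond the scatter, but two cores are too few to show that it would behave the same way on any further core.

The compounds shown leave open what other groups would do at this same place, such as a methoxy group or a dimethylamino group. They also leave open why the amino compounds give the numbers they do.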